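Amide side chain change on compound 2

The source may hold more compounds than are shown below. What is called first, only, known or untested is meant among the compounds shown, and "the series" means these compounds.

compound 1 `CCCCC(=O)c1ccc(C(CC)(CC)c2ccc(C#CC(O)(CC)CC)c(C)c2)n1CC`: > 50000 nM (a limit)
compound 2 `CCn1cc(C(CC)(CC)c2ccc(C#CC(O)(CC)CC)c(C)c2)cc1C(=O)NCCN(C)C`: 10100 nM

Among the measured compounds shown here, in a functional assay on PC-3 cells (Homo sapiens) for antiproliferative activity, read by MTT assay, with a stated time of 72 h (a lower number here means a stronger inhibitor, a higher number a weaker inhibitor), compound 2 gives 10100 nM as the only actual number so far. Compound 1 stands at > 50000 nM in the same test, and this is a limit, not a number.

Compound 3 `CCn1cc(C(CC)(CC)c2ccc(C#CC(O)(CC)CC)c(C)c2)cc1C(=O)N[C@H](C(=O)O)C(C)C` keeps the shared core and the amide of compound 2. It changes only the group on the amide-type nitrogen, with 1-carboxy-2-methylpropyl in place of 2-(dimethylamino)ethyl on an amide-type nitrogen as the whole difference.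

For the measured compounds named here, no measured pair isolates this change, so the expectation rests on compound 2 at 10100 nM as its single anchor. The central expectation is no step beyond the scatter, with a lean toward weaker inhibition, and the expected change is a 1.5-fold higher number from compound 2 to compound 3 (0.17 log units; within the scatter) with wide uncertainty on either side. In this assay compound 3 is estimated at 15000 nM with a range of 3000 nM to 50000 nM as the expected bounds.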

Compound 3, half-maximal inhibitory concentration: 3750 nM
Compound 3: middle estimate off by 4.0-fold (0.60 log units), on the high side; the range from low to high includes it.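

In this assay, among the compounds shown here, the group on the amide-type nitrogen now has a measured effect: 1-carboxy-2-methylpropyl in place of 2-(dimethylamino)ethyl gives a 2.7-fold lower number from compound 2 to compound 3 (0.43 log units; beyond the scatter) as the first step that can be read, modest in size but beyond the scatter. The earlier compounds shown here offered no pair at this position, and this pair shows that the 2-(dimethylamino)ethyl group is not required for the activity of the shared core in this test, since the chain carrying a carboxy group and a defined stereocentre gives the lower number. Nothing shown accounts for the step, and the single limit in the series has no bearing on it.

The change to compound 3 alters the carboxy group, the branched chain and the stereocentre in one move, and the compounds shown do not separate these three features. A methyl ester in place of the carboxylic acid, an unbranched carboxymethyl chain on the same nitrogen, or the opposite stereocentre would each test one of these features alone.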